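Chain Length and Stereochemistry in a Histone Deacetylase Series

The source may report more compounds than this note shows. Statements on the series, on what has been measured and on what is new or still open speak of the compounds shown alone.

Compound 1, `Nc1ccccc1NC(=O)/C=C/c1cn([C@@H]2C[C@@H](C(=O)O)N(Cc3ccccc3)C2)nn1`: < 10%
Compound 2, `Nc1ccccc1NC(=O)/C=C/c1cn([C@@H]2C[C@@H](C(=O)O)N(CCCc3ccccc3)C2)nn1`: < 10%
Compound 3, `Nc1ccccc1NC(=O)/C=C/c1cn([C@H]2C[C@H](C(=O)O)N(Cc3ccccc3)C2)nn1`: < 10%

Three compounds were tested in an assay on cells for inhibition of histone deacetylase 11 (Homo sapiens), read by fluorescence, with stated times of 3 h and 30 min, tested at 2 uM, in the presence of a further agent that is not named here; a higher number here means more inhibition at the concentration tested (going by the name of the read-out), a lower number less inhibition. In this assay compound 1 gives < 10%, which is a limit of the assay and not a number. Compound 2 gives < 10%, again a limit. Compound 3 gives < 10%, also a limit.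

Compound 2 differs from compound 1 by phenethyl in place of phenyl on a saturated chain carbon bound to an amine nitrogen in a ring. The size of the step that the two limits leave unreadable from compound 1 to compound 2 cannot be read because of the limit of < 10% in this assay, at which 3 of the 3 values shown sit. Compound 3 shares all atoms and bonds with compound 1 and differs only in its core: the two compounds have the same atoms and bonds and differ only in configuration as drawn: 2 of 3 stereo elements differ; a stereocentre at a saturated ring carbon is drawn R in compound 1 and S in compound 3; a stereocentre at a saturated ring carbon is drawn S in compound 1 and R in compound 3. The step that the two limits leave unreadable from compound 1 to compound 3 is likewise unreadable because of the limit of < 10% in this assay, at which 3 of the 3 values shown sit, even though the fact that compounds 1 and 3 differ only in the configuration as drawn makes the pair a clean comparison of configuration alone.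

Compound 4, `Nc1ccccc1NC(=O)/C=C/c1cn([C@H]2C[C@H](C(=O)O)N(CCCc3ccccc3)C2)nn1`, is not yet measured. It differs from compound 3 by phenethyl in place of phenyl on a saturated chain carbon bound to an amine nitrogen in a ring. This is the same change as from compound 1 to compound 2, made at the same place, and it occurs twice among the compounds shown. The step from compound 3 to compound 4 is expected to be a step that the limit leaves unreadable from compound 3 to compound 4, an expectation that rests on the step that the two limits leave unreadable from compound 1 to compound 2 having left both compounds at the limit. Compound 4 is therefore expected to give 5% in this assay, most likely again as a limit, with a range from 0% to 15%.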

Compound 4, a percentage reported as inhibition, at one concentration (the size of the read-out at that concentration, not a potency): < 10%
Compound 4 was reported as a limit; the forecaster's own chance of this, stated with the estimate: 85%; the middle value is on the limit's open side.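

In this assay compound 4 gives < 10%, which is a limit of the assay and not a number. The steps from compound 3 to compound 4 and from compound 2 to compound 4 cannot be read, for one reason shared by both: the limit of < 10% in this assay, at which 4 of the 4 values shown sit.

The compounds shown leave open whether the change from benzyl to 3-phenylpropyl, or the configuration as drawn, alters inhibition at all.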